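This account rests on a few compounds, and the source may have more. Where it says the series, first, only, none or still open, it means among the compounds named here.

In a functional assay for inhibition, with Homo sapiens as the target (a lower number here means a stronger inhibitor, a higher number a weaker inhibitor), compound 1 (`Clc1ccccc1C(CC1CCCCC1)Nc1nc2ccccc2o1`) gives 80 nM and compound 2 (`CNC(=O)C(CC1CCCCC1)Nc1nc2cc(C)ccc2o1`) gives 72 nM. These two numbers lie within the usual scatter of each other, so compound 2 cannot be separated from compound 1. Compound 3 (`Cc1ccc2oc(NC(CC3CCCCC3)c3cccnc3)nc2c1`) has pyridin-3-yl in place of methylcarbamoyl on a saturated chain carbon bound to a nitrogen on an aromatic ring and a saturated chain carbon. Going by the values given here, no measured pair differs in one place only, so this change has no direct precedent. The nearest guide is compound 1, which also carries a six-membered aromatic ring on that chain carbon and gives 80 nM. Only a small move in this assay towards a higher number is therefore expected, within the scatter. The estimated step is a 1.4-fold higher number from compound 2 to compound 3 (0.14 log units; within the scatter). For compound 3 the expected value is 100 nM, with an estimated range of 30 nM to 350 nM.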

Compound 3, half-maximal inhibitory concentration: 20 nM
Beside the measured number, compound 3's estimate is 5.0-fold (0.70 log units) above it; measured number below the stated range.
By their numbers in this assay, from the lowest: compound 3; then compounds 2 and 1 (each within the scatter of the next).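

In this assay, going by these compounds alone, pyridin-3-yl in place of methylcarbamoyl on a saturated chain carbon bound to a nitrogen on an aromatic ring and a saturated chain carbon gives a 3.6-fold lower number from compound 2 to compound 3 (0.56 log units; beyond the scatter), the first single-place step at this position. The position therefore accepts a six-membered aromatic ring with 1 hetero atom in place of a group with no ring, and the number falls even though the hydrogen-bond donor of methylcarbamoyl is gone. Nothing available here accounts for this step.

Compound 1 differs from compound 3 in more than one place, so the compounds shown do not separate the part played by the ring from that of its nitrogen. A plain phenyl at this position on the same core would address that question, and pyridin-2-yl or pyridin-4-yl would show whether the placing of the ring nitrogen matters.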